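The compounds below may be only part of what the source reports. "The series", "measured", "known", "first", "only" and "open" are said of these compounds alone.

Compound 1 `Cc1ccc(-n2nc(C(=O)Nc3ccc(Oc4ncnc5[nH]ccc45)cc3)c(C)cc2=O)cc1` gives 6400 nM in a functional assay on A549 cells (Homo sapiens) for cytotoxicity, read by MTT assay, with a stated time of 72 h; on this read-out lower numbers stand for stronger inhibition and higher numbers for weaker inhibition. Of the two numbers recorded it is the smaller one, but the gap to compound 2 `Cc1cc(=O)n(-c2cccc(C(F)(F)F)c2)nc1C(=O)Nc1ccc(Oc2ncnc3[nH]ccc23)cc1`, which gives 7570 nM, is within the scatter, so the two cannot be told apart. Among the measured compounds shown here, the only measured step, a 1.2-fold higher number from compound 1 to compound 2 (0.07 log units; within the scatter), exchanges the ring on the aromatic nitrogen and leaves the numbers essentially unchanged. Compound 3 `Cc1ccc(-n2nc(C(=O)Nc3ccc(Oc4ncnc5[nH]ccc45)c(F)c3)c(C)cc2=O)cc1` differs from compound 1 at a different place: fluoro in place of hydrogen on an aromatic carbon, on a six-membered aromatic ring of carbon only, ortho to a large group and meta to a large group. For the measured compounds named here, no measured pair shows what a fluoro entering there does, so there is no direct precedent. The expectation for compound 3 is therefore a step of about no change at the digits printed from compound 1 to compound 3 (within the scatter) in this assay, nothing beyond the scatter. Compound 3 is estimated at 6400 nM, between 2500 nM and 16000 nM.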

Compound 3, half-maximal inhibitory concentration: 18500 nM
The estimate for compound 3 lay 2.9-fold (0.46 log units) below the measured number, outside the stated range (above it).
By their numbers in this assay, from the lowest: compounds 1 and 2 (each within the scatter of the next); then compound 3.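

In this assay, fluoro in place of hydrogen on this aromatic carbon, ortho to a large group and meta to a large group, gives a 2.9-fold higher number from compound 1 to compound 3 (0.46 log units; beyond the scatter), a modest move towards weaker inhibition from a change of a single heavy atom. The earlier exchange of the ring on the aromatic nitrogen stayed within the scatter, so this carbon is the first place among the compounds shown where a change moves the number beyond it. No measurement at hand accounts for this loss.

From the compounds shown here alone, whether a chloro, a methyl or an amine on the same carbon would raise the number as fluoro does remains open. Also open, going by these compounds, is whether fluoro there would give a similar step in compound 2, which carries 3-(trifluoromethyl)phenyl on the aromatic nitrogen.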